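Hydroxyphenyl hydrazone series: second hydroxy group on compound 2

A few compounds are considered here, and "the series" means these few. Any claim that something is new, unique, unknown or untested is made for them only; others in the source may bear on it.

Measured in a functional assay on EC9706 cells (Homo sapiens) for antiproliferative activity, read by MTT assay, with a stated time of 72 h; on this read-out higher numbers stand for weaker inhibition and lower numbers for stronger inhibition:
compound 1, `C/C(=N\NC(=O)c1cccc(S(=O)(=O)N2CCOCC2)c1)c1ccccc1O`, gives 1220 nM.
compound 2, `C/C(=N\NC(=O)c1cccc(S(=O)(=O)N2CCOCC2)c1)c1cccc(O)c1`, gives > 100000 nM; this is a limit of the assay, not a number.
compound 3, `C/C(=N\NC(=O)c1cccc(S(=O)(=O)N2CCOCC2)c1)c1cc(O)ccc1O`, not yet measured.

Compound 2 stands at the weak end of what has been measured: its value is only a limit, (the limit of > 100000 nM in this assay, at which 1 of the 2 values shown sits). For the measured compounds named here, the single measured step, an at least 81-fold higher number from compound 1 to compound 2 (1.91 log units; beyond the scatter), is therefore itself open-ended on the weak side.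

The change from compound 2 to compound 3 is hydroxy in place of hydrogen on an aromatic carbon. It puts a hydroxy onto the ring of compound 2 at the place that carries the hydroxy in compound 1, while the hydroxy of compound 2 is kept. The measured step from compound 1 to compound 2 bears on this directly: removing the hydroxy from that place cost an at least 81-fold higher number from compound 1 to compound 2 (1.91 log units; beyond the scatter). Restoring it is expected to reverse much of that loss, since compound 1 gives 1220 nM. Whether the retained hydroxy of compound 2 adds or subtracts is not covered by any measured pair, so the expected value for compound 3 is kept near compound 1 with a wide range: 2500 nM, between 500 nM and 25000 nM, an estimated step of an at least 40-fold lower number from compound 2 to compound 3 (1.60 log units; beyond the scatter).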

Compound 3, half-maximal inhibitory concentration: 3510 nM
Estimate against measurement, compound 3: 1.4-fold (0.15 log units) below; low and high end bracket the measured number.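

In this assay, the hydroxy entering ortho to a large group and para to the hydroxy of compound 2 brings an at least 28-fold lower number from compound 2 to compound 3 (1.45 log units; beyond the scatter), so a hydroxy at this position restores activity even with the 3-hydroxy retained. This step is open-ended on the weak side, as compound 2 gives only a limit: the limit of > 100000 nM in this assay, at which 1 of the 3 values shown sits.

Read from the other side, the change from 2-hydroxyphenyl to 2,5-dihydroxyphenyl gives a 2.9-fold higher number from compound 1 to compound 3 (0.46 log units; beyond the scatter), so across these three compounds a further hydroxy costs only modestly when the hydroxy ortho to the large group is present, and both compounds carrying that hydroxy sit well away from the limit.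

The compounds shown leave open whether the hydroxy ortho to the large group can be replaced, for instance by a methoxy, an amine or a fluorine, and so whether a free hydroxy is what this position requires. They also leave open whether the modest step belongs to a hydroxy specifically, since a methoxy, a chlorine or a carboxylic acid para to the first hydroxy would be needed to separate the effect of that group from that of its place.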